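The source may report more compounds than this note shows. Statements on the series, on what has been measured and on what is new or still open speak of the compounds shown alone.

Measured so far:
Compound 1, `CNCc1nnc(-c2ccccc2-c2ccccc2)s1`, with 25 mg/kg in a functional assay on the whole organism with Mus musculus as the target; a lower number here means that less compound is needed, a higher number that more compound is needed for the effect
Compound 2, `CCCCCCOc1ccccc1-c1nnc(CN)s1`, with 34 mg/kg in this assay

Among the measured compounds shown here, only these two numbers are known, and they come from compounds that differ in more than one place, so no single step between measured compounds can be read from them. Compound 2 stands with compound 1 inside the usual scatter; the two values cannot be told apart. Compound 3, `CCCCCCOc1ccccc1-c1nnc(CNC)s1`, is the next to be measured. It differs from compound 2 in one place: methyl in place of hydrogen on an amine nitrogen. Nothing in the measured pair shows what such a change does on its own in this assay. For the measured compounds named here, the only guidance is that compound 1, which carries the same methylamino group on a different core, gives a number in the same range as compound 2. The expectation is therefore a step of no more than the scatter, in no particular direction. Compound 3 is expected to give about 30 mg/kg, with a likely range from 12 mg/kg to 80 mg/kg. That estimate corresponds to an expected step of a 1.1-fold lower number from compound 2 to compound 3 (0.05 log units; within the scatter).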

Compound 3, dose for half-maximal effect: 44 mg/kg
The estimate for compound 3 lay 1.5-fold (0.17 log units) below the measured number; measured number inside the range.
By their numbers in this assay, from the lowest: compounds 1, 2 and 3 (each within the scatter of the next).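

Holding the hexyloxy compound fixed gives the first reading of a single change at this amine nitrogen. In this assay, methyl in place of hydrogen comes with a 1.3-fold higher number from compound 2 to compound 3 (0.11 log units; within the scatter) and so leaves the two compounds indistinguishable, which means that this small addition has no effect here that can be told apart from the scatter. With the methylamino group held constant, hexyloxy in place of phenyl on an aromatic carbon comes with a 1.8-fold higher number from compound 1 to compound 3 (0.25 log units; within the scatter) in this assay, so that exchange also gives no separable difference, and no measurement available here bears on the reason for either result.

Still open, going by these compounds, is whether a larger group on this nitrogen, such as ethyl, isopropyl or acetyl, or a hydroxyl in place of the amine, would give a step beyond the scatter. Also open, on these data alone, is how a shorter chain such as butoxy, a longer chain such as octyloxy, or a methoxy group in place of hexyloxy would read in this assay with either the amino or the methylamino group present.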